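The source may report more compounds than this note shows. Statements on the series, on what has been measured and on what is new or still open speak of the compounds shown alone.

In a functional assay on MDA-MB-231 cells (Homo sapiens) for antiproliferative activity, read by MTT assay, with a stated time of 72 h (a lower number here means a stronger inhibitor, a higher number a weaker inhibitor), compound 1 (`O=C(CCc1cccc2c1B(O)OC2)Nc1ccccc1`) gives 230 nM and compound 2 (`O=C(CCc1cccc2c1B(O)OC2)Nc1ccc(Cl)cc1`) gives 3600 nM, while compound 3 (`O=C(CCc1cccc2c1B(O)OC2)Nc1ccc(I)cc1`) gives 33000 nM as the highest number of the three, which makes it the weakest inhibitor measured so far. Compound 4 (`C#Cc1ccc(NC(=O)CCc2cccc3c2B(O)OC3)cc1`) carries ethynyl in place of iodo on an aromatic carbon para to a large group.

Chloro in place of hydrogen gave a 16-fold higher number from compound 1 to compound 2 (1.19 log units; beyond the scatter) and iodo in place of hydrogen gave a 140-fold higher number from compound 1 to compound 3 (2.16 log units; beyond the scatter) as large steps, while iodo in place of chloro gave a 9.2-fold higher number from compound 2 to compound 3 (0.96 log units; beyond the scatter) as a modest one. Among the measured compounds shown here, both substituted compounds are weaker than compound 1, and no measured compound goes against this, though only compound 2 and compound 3 test it. For the measured compounds named here, no ethynyl compound has been measured, so these steps guide the expectation only loosely.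

With compound 3 at the weak end of the numbers, a modest step toward a lower number is expected, with compound 4 still weaker than compound 1. The estimated change is a 5.5-fold lower number from compound 3 to compound 4 (0.74 log units; beyond the scatter) on this reading. In this assay the estimate for compound 4 is 6000 nM within an expected range of 1500 nM to 25000 nM.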

Compound 4, half-maximal inhibitory concentration: 6600 nM
Beside the measured number, compound 4's estimate is 1.1-fold (0.04 log units) below it, within the range that was stated.
By their numbers in this assay, from the lowest: compound 1; then compounds 2 and 4 (each within the scatter of the next); then compound 3.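

In this assay, iodo is not the limit for every group at this position para to a large group: ethynyl in place of iodo gives a 5.0-fold lower number from compound 3 to compound 4 (0.70 log units; beyond the scatter) as a modest recovery, yet ethynyl in place of chloro gives a 1.8-fold higher number from compound 2 to compound 4 (0.26 log units; within the scatter) within the scatter, so compound 2 and compound 4 cannot be separated, and the ethynyl compound sits with the chloro compound rather than the iodo compound. Hydrogen remains the reference, since ethynyl in place of hydrogen gives a 29-fold higher number from compound 1 to compound 4 (1.46 log units; beyond the scatter) as a large step, which makes compound 4 the third substituted compound weaker than compound 1, and none of the compounds shown goes against this. Nothing in hand accounts for the gap between ethynyl and iodo or for the shared loss against hydrogen.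

From the compounds shown here alone, whether fluoro, methoxy, a nitrile, an amine or a carboxylic acid at this position would bring the number back toward that of compound 1 stays open. Also open, going by these compounds, is whether ethynyl or chloro elsewhere on the same aromatic ring would carry the same loss.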